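Cyclopropyl to methyl on the shared core

This account rests on a few compounds, and the source may have more. Where it says the series, first, only, none or still open, it means among the compounds named here.

Compound 1 `COc1ccc(-c2cc(=O)n(Cc3cccnc3)nc2-c2ccc(OC)cc2)cc1` gives 430 nM
Compound 2 `COc1ccc(-c2cc(=O)n(C3CC3)nc2-c2ccc(OC)cc2)cc1` gives 7980 nM

In a functional assay on HL-60 cells (Homo sapiens) for inhibition (a higher number here means a weaker inhibitor, a lower number a stronger inhibitor), compound 2 holds the higher of the two numbers (7980 nM) and so stands as the weaker inhibitor of the pair. Compound 3 `COc1ccc(-c2cc(=O)n(C)nc2-c2ccc(OC)cc2)cc1` has methyl in place of cyclopropyl on an aromatic nitrogen and has not yet been measured. For the measured compounds named here, the one measured step at this nitrogen is large: a 19-fold higher number from compound 1 to compound 2 (1.27 log units; beyond the scatter) and it brought in cyclopropyl in place of (pyridin-3-yl)methyl. Going by the values given here, that step removed the pyridinylmethyl group, which is also absent from compound 3, and no measured step compares cyclopropyl with methyl directly. No change beyond the scatter is therefore expected in this assay, in either direction. The expected step is a 1.1-fold lower number from compound 2 to compound 3 (0.06 log units; within the scatter) and no more. For compound 3 the estimated value is 7000 nM within an expected range of 2000 nM to 25000 nM.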

Compound 3, half-maximal inhibitory concentration: 1130 nM
Estimate against measurement, compound 3: 6.2-fold (0.79 log units) above; the whole stated range lies above it.
By their numbers in this assay, from the lowest: compound 1; then compound 3; then compound 2.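

In this assay the group on this aromatic nitrogen still counts once the pyridine ring is gone, with a 7.1-fold lower number from compound 2 to compound 3 (0.85 log units; beyond the scatter) for methyl in place of cyclopropyl, so these two groups are not interchangeable here. Replacing pyridin-3-yl with hydrogen on the chain carbon bound to the aromatic nitrogen gives a 2.6-fold higher number from compound 1 to compound 3 (0.42 log units; beyond the scatter). For the compounds shown here, that is a smaller step than the one from compound 1 to compound 2, so much of that earlier loss goes with cyclopropyl rather than with losing the pyridine ring alone. Nothing available explains either step.

The compounds shown leave open how a longer chain such as ethyl or propyl would fare on this nitrogen. They also leave open whether a plain benzyl group would match the (pyridin-3-yl)methyl group of compound 1.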